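This account rests on a few compounds, and the source may have more. Where it says the series, first, only, none or still open, it means among the compounds named here.

Compound 3 `O=C(O)CC/C=C\CC1COC(c2cccnc2)OC1c1cccnc1` is the weakest of the three measured compounds in an assay for inhibition of Thromboxane-A synthase (Homo sapiens), using microsomes (a lower number here means a stronger inhibitor, a higher number a weaker inhibitor), where compound 3 gives 220 nM. Compound 1 `N#Cc1ccc(C2OCC(C/C=C\CCC(=O)O)C(c3cccnc3)O2)cc1` gives 24 nM in this assay, and compound 2 `O=C(O)CC/C=C\CC1COC(c2ccc([N+](=O)[O-])cc2)OC1c1cccnc1` gives 39 nM; the step from compound 1 to compound 2 is a 1.6-fold higher number from compound 1 to compound 2 (0.21 log units; within the scatter), so those two cannot be ordered. The steps that set compound 3 apart are a 9.2-fold higher number from compound 1 to compound 3 (0.96 log units; beyond the scatter) and a 5.6-fold higher number from compound 2 to compound 3 (0.75 log units; beyond the scatter), both at the same saturated ring carbon that is changed again here.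

Compound 4 `O=C(O)CC/C=C\CC1COC(c2ccc3ccccc3c2)OC1c1cccnc1` differs from compound 3 by naphthalen-2-yl in place of pyridin-3-yl on a saturated ring carbon. Both measured steps at this position show that a pyridin-3-yl group there gives a higher number than a carbocyclic aromatic group, and the change to compound 4 runs the other way, toward a carbocyclic aromatic group. Within the data shown here, no measured compound carries a naphthalen-2-yl group, so the size of the reversal is uncertain. Compound 4 is therefore expected to show a step of a 4.9-fold lower number from compound 3 to compound 4 (0.69 log units; beyond the scatter) in this assay, and its value is estimated at 45 nM, within a range from 12 nM to 170 nM.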

Compound 4, half-maximal inhibitory concentration: 50 nM
Compound 4: the middle estimate sits 1.1-fold (0.05 log units) below what was measured; low and high end bracket the measured number.
By their numbers in this assay, from the lowest: compounds 1, 2 and 4 (each within the scatter of the next, the first and the last beyond it); then compound 3.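

In this assay, naphthalen-2-yl in place of pyridin-3-yl on the saturated ring carbon between two ring oxygen atoms gives a 4.4-fold lower number from compound 3 to compound 4 (0.64 log units; beyond the scatter), so a third carbocyclic aromatic group now stands apart from pyridin-3-yl, and this time the group has two rings and no hydrogen-bond acceptor. The two-ring group is not separated from 4-nitrophenyl, with a 1.3-fold higher number from compound 2 to compound 4 (0.11 log units; within the scatter), but it is separated from 4-cyanophenyl, with a 2.1-fold higher number from compound 1 to compound 4 (0.32 log units; beyond the scatter). A nitrile or nitro substituent is therefore not required for a number well under that of compound 3, although only 4-cyanophenyl stands apart from naphthalen-2-yl.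

The data shown offer no evidence that explains these differences. As far as these compounds go, how a plain phenyl group, a 4-aminophenyl group or a naphthalen-1-yl group would compare at this carbon remains open.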